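A few compounds are considered here, and "the series" means these few. Any claim that something is new, unique, unknown or untested is made for them only; others in the source may bear on it.

Working notes on the series. In a functional assay on CCRF-CEM cells (Homo sapiens) for inhibition, read by cell counting, with a stated time of 3 days (on this read-out higher numbers stand for weaker inhibition and lower numbers for stronger inhibition), compound 2 `C=C(Br)C(=O)Nc1cccc(-c2cn3nc(-c4ccc(OCC)cc4)sc3n2)c1` gives 1400 nM. Compound 3 `C=C(Br)C(=O)Nc1cccc(-c2cn3nc(-c4cccc(OC)c4)sc3n2)c1` gives 1200 nM in this assay. The two cores differ by 3-methoxyphenyl in place of 4-ethoxyphenyl on an aromatic carbon, and that step runs a 1.2-fold lower number from compound 2 to compound 3 (0.07 log units; within the scatter). Compound 1 `CCOc1ccc(-c2nn3cc(-c4cccc(N)c4)nc3s2)cc1` is reported in this assay only as a limit, > 250000 nM. The change hydrogen in place of (1-bromoethenyl)carbonyl on a nitrogen on an aromatic ring gives an at least 170-fold higher number from compound 2 to compound 1 (2.25 log units; beyond the scatter), a step whose size is known only as a bound because compound 1 sits at the limit of > 250000 nM in this assay, at which 1 of the 3 values shown sits. Compound 4 `COc1cccc(-c2nn3cc(-c4cccc(N)c4)nc3s2)c1` is not yet measured. It differs from compound 3 by hydrogen in place of (1-bromoethenyl)carbonyl on a nitrogen on an aromatic ring, the same change as from compound 2 to compound 1, the place being identical word for word in both. For compound 4 the expected step is a 210-fold higher number from compound 3 to compound 4 (2.32 log units; beyond the scatter), resting on an at least 170-fold higher number from compound 2 to compound 1 (2.25 log units; beyond the scatter). Compound 4 is estimated at 250000 nM, in a range from 50000 nM to 1000000 nM, most probably reported only as a limit.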

Compound 4, half-maximal inhibitory concentration: > 250000 nM
Compound 4 gave a limit, no number (the forecaster's own chance of this, stated with the estimate: 85%); the middle value lies on the limit itself.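

Setting hydrogen in place of (1-bromoethenyl)carbonyl on the nitrogen gives an at least 200-fold higher number from compound 3 to compound 4 (2.31 log units; beyond the scatter) in this assay. The 3-methoxyphenyl core thus follows the 4-ethoxyphenyl core, with a large step in the same direction on both: the same change on two cores in this assay, an at least 170-fold higher number (2.25 log units; beyond the scatter) from compound 2 to compound 1 and an at least 200-fold higher number (2.31 log units; beyond the scatter) from compound 3 to compound 4; the limit leaves it open whether they differ This does not show that the size of the step is equal on the two cores, or that it would hold on any other core, as both amino compounds end at a limit and each step is known only as a bound: the limit of > 250000 nM in this assay, at which 2 of the 4 values shown sit.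

Open, going by these compounds, is whether the bromine matters, as an acetyl or a plain propenoyl group on the same nitrogen would show. Also open, on these data alone, is whether the step holds with a carboxylic acid or a longer alkoxy chain on the phenyl ring.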